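The compounds below may be only part of what the source reports. "The series", "measured", "known", "first", "only" and "open" are said of these compounds alone.

Three compounds have been measured in a functional assay on HepG2 cells (Homo sapiens) for cytotoxicity, read by MTT assay, with a stated time of 24 h; a lower number here means a stronger inhibitor, a higher number a weaker inhibitor:
Compound 1, `CN1C/C(=C\c2cccnc2)C(=O)/C(=C/c2ccc(F)cc2Br)C1`, gives 13000 nM.
Compound 2, `CN1C/C(=C\c2ccc(C(F)(F)F)cc2)C(=O)/C(=C/c2cccnc2)C1`, gives 4790 nM.
Compound 3, `CN1C/C(=C\c2ccncc2)C(=O)/C(=C/c2ccc(F)cc2Br)C1`, gives 9200 nM.

Compound 3 arises from compound 1 by a single change, (pyridin-4-yl in place of pyridin-3-yl on a double-bonded chain carbon bound to a double-bonded ring carbon), and this change made the step of a 1.4-fold lower number from compound 1 to compound 3 (0.15 log units; within the scatter). The difference between the core of compound 1 and that of compound 2 is not broken down here. Compound 4, `CN1C/C(=C\c2ccncc2)C(=O)/C(=C/c2ccc(C(F)(F)F)cc2)C1`, has not yet been measured; it stands to compound 2 exactly as compound 3 stands to compound 1, through the same change, (pyridin-4-yl in place of pyridin-3-yl on a double-bonded chain carbon bound to a double-bonded ring carbon). Because the earlier change produced only a 1.4-fold lower number from compound 1 to compound 3 (0.15 log units; within the scatter), a step of similar and modest size is expected here, a 1.3-fold lower number from compound 2 to compound 4 (0.10 log units; within the scatter). Compound 4 is therefore estimated at 3800 nM, most likely falling between 1800 nM and 8000 nM.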

Compound 4, half-maximal inhibitory concentration: 8200 nM
The estimate for compound 4 lay 2.2-fold (0.33 log units) below the measured number, outside the stated range (above it).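

In this assay, placing pyridin-4-yl where pyridin-3-yl stood gave a 1.7-fold higher number from compound 2 to compound 4 (0.23 log units; within the scatter). Set beside the same change on the other core, the two steps do not differ beyond the scatter: the same change on two cores in this assay, a 1.4-fold lower number (0.15 log units; within the scatter) from compound 1 to compound 3 and a 1.7-fold higher number (0.23 log units; within the scatter) from compound 2 to compound 4, 2.4-fold (0.38 log units) apart, within the scatter of two such steps. This shows that, on these two cores, the change moved the number by no more than the scatter and that the cores cannot be told apart in their response, but it does not show that they respond identically or that the same would hold on any further core.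

The compounds shown leave open what pyridin-2-yl would give in place of pyridin-3-yl or pyridin-4-yl. They also leave open whether the step stays this small on a core carrying a methoxy group or a nitrile instead of trifluoromethyl.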